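Methoxy on the benzyl arm of the shared core

The source may hold more compounds than are shown below. What is called first, only, known or untested is meant among the compounds shown, and "the series" means these compounds.

Measured so far:
compound 1 `COc1ccc(CNc2nc([Se]C)nc3ccccc23)cc1` gives 98600 nM in a functional assay on MCF7 cells (Homo sapiens) for cytotoxicity, read by MTT assay, with a stated time of 72 h; on this read-out lower numbers stand for stronger inhibition of growth and higher numbers for weaker inhibition of growth
compound 2 `Sc1nc(NCc2ccccc2)c2ccccc2n1` gives > 100000 nM in this assay
compound 3 `CSc1nc(NCc2ccccc2)c2ccccc2n1` gives 82800 nM in this assay

For compound 2 the value > 100000 nM is a limit of the assay, not a number, so compound 2 stands only at the edge of the range shown, (the limit of > 100000 nM in this assay, at which 1 of the 3 values shown sits). For the measured compounds named here, the one measured step in this set, an at least 1.2-fold lower number from compound 2 to compound 3 (0.08 log units; that floor lies within the scatter), is methyl in place of hydrogen on a sulfur and gives only a floor. Compound 4 `COc1ccc(CNc2nc(S)nc3ccccc23)cc1` keeps the core of compound 2 and differs from it in one place: methoxy in place of hydrogen on an aromatic carbon. Going by the values given here, no measured step covers the methoxy change on its own. Compound 1 and compound 3 differ from each other in two places, the methoxy and the selenium-methyl against the thiomethyl, and compound 1 gives 98600 nM while compound 3 gives 82800 nM, two numbers near each other. The expectation for compound 4 in this assay is therefore a step that the limit leaves unreadable from compound 2 to compound 4, that is, none beyond the scatter, with a real chance that the assay again reports only a limit. Compound 4 is estimated at 120000 nM, within 60000 nM to 300000 nM.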

Compound 4, concentration for total growth inhibition: 36500 nM
Estimate against measurement, compound 4: 3.3-fold (0.52 log units) above, outside the stated range (below it).
By their numbers in this assay, from the lowest: compound 4; then compounds 3 and 1 (each within the scatter of the next). At a limit, above all of these: compound 2.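

In this assay, methoxy in place of hydrogen on an aromatic carbon of the benzyl arm, para to a large group, gives an at least 2.7-fold lower number from compound 2 to compound 4 (0.43 log units; beyond the scatter), so this position responds to the change by more than the scatter, which the step on the sulfur did not show in an at least 1.2-fold lower number from compound 2 to compound 3 (0.08 log units; that floor lies within the scatter). Compound 2 stands at a limit of the assay, not at a number, which makes the methoxy step a floor: the limit of > 100000 nM in this assay, at which 1 of the 4 values shown sits. With the methoxy kept on the arm, one sulfur atom in place of the group of 2 heavy atoms (1 carbon, 1 selenium) gives a 2.7-fold lower number from compound 1 to compound 4 (0.43 log units; beyond the scatter), which shows that the methoxy step depends on what sits on the other side of the shared core, or at least that this second place also counts.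

The compounds shown hold no pair that tests the methoxy with a thiomethyl in place, so it stays open whether the step carries over to that setting. Also open, as far as these compounds go, is how a hydroxy group or an amine on the benzyl arm, or a longer chain on the sulfur, would compare with compound 4 at 36500 nM.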